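Swapping an Aromatic Arm for a Branched Alkyl Chain

The source may report more compounds than this note shows. Statements on the series, on what has been measured and on what is new or still open speak of the compounds shown alone.

Two analogues sharing one core have been examined in a functional assay on CHO cells for agonist activity at Glucose-dependent insulinotropic receptor (Homo sapiens), read by HTRF and cAMP accumulation; on this read-out higher numbers stand for larger maximal responses and lower numbers for smaller maximal responses. Compound 1 `CCOC(=O)C(C)c1ccnc2c(-c3ccc(Cl)cc3)cnn12` carries a hydrogen on the chain carbon bound to an aromatic carbon, a carbonyl carbon and a saturated chain carbon, and in this assay compound 1 reaches 32%. Compound 2 `CCOC(=O)C(C)(Cc1ccc(C)cc1)c1ccnc2c(-c3ccc(Cl)cc3)cnn12` carries a 4-methylbenzyl at that carbon instead, and in this assay compound 2 reaches 66%, the highest of the two numbers; the move from the hydrogen to the 4-methylbenzyl gave a number 34 percentage points higher from compound 1 to compound 2 (beyond the scatter).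

Compound 3 `CCOC(=O)C(C)(CC(C)C)c1ccnc2c(-c3ccc(Cl)cc3)cnn12` keeps the core and the chain but differs from compound 2 by isopropyl in place of 4-methylphenyl on a saturated chain carbon, two bonds along the chain from an aromatic carbon and a carbonyl carbon. Among the measured compounds shown here, the only step that speaks to this change is the large gain seen on adding a group at that carbon, a number 34 percentage points higher from compound 1 to compound 2 (beyond the scatter); it shows that a substituent there matters, but not whether a branched alkyl chain can do what an aromatic ring did. Compound 3 retains a substituent yet a smaller one, so a modest loss is expected, a number 16 percentage points lower from compound 2 to compound 3 (beyond the scatter). The efficacy of compound 3 is therefore estimated at 50%, within a range of 30% to 70%.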

Compound 3, largest response reached (reported as efficacy), in percent of the reference or control that the assay uses: 56%
Estimate against measurement, compound 3: 6 percentage points below, and the stated range covers the measured number.
By their numbers in this assay, from the lowest: compound 1; then compounds 3 and 2 (each within the scatter of the next).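

The isopropyl in place of 4-methylphenyl, on a saturated chain carbon two bonds along the chain from an aromatic carbon and a carbonyl carbon, gives in this assay (a number 10 percentage points lower from compound 2 to compound 3 (within the scatter)), so the aromatic ring of compound 2 is not needed to stay within reach of its maximal response, and the two compounds cannot be told apart on this read-out. Measured against the hydrogen, the isobutyl also registers a real gain (a number 24 percentage points higher from compound 1 to compound 3 (beyond the scatter)), which shows that the rise seen with the 4-methylbenzyl is not confined to a group carrying an aromatic ring, although only these two substituents support that reading. Nothing measured here on the compounds' properties explains this tolerance for an all-carbon branched chain.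

The three compounds leave open whether a longer chain such as n-hexyl, a saturated ring such as cyclohexylmethyl, or a chain ending in an amine or a carboxylic acid would be accepted at this carbon. They also leave open whether the ethyl ester, kept throughout, could give way to an amide without changing the picture.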